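The source may report more compounds than this note shows. Statements on the series, on what has been measured and on what is new or still open speak of the compounds shown alone.

Measured compounds:
- compound 1 `CCCCCCCCCCc1ccc(-c2noc([C@@H]3CC[C@H](N)C3)n2)cc1`: in an assay on HeLa cells for inhibition of sphingosine-1-phosphate transporter SPNS2 (Mus musculus), read by LC-MS, tested at 2 uM (a lower number here means less inhibition, a higher number more inhibition at the concentration tested (going by the name of the read-out)), compound 1 gives 38%
- compound 2 `CCCCCCCCCCc1ccc(-c2noc([C@@H](N)CCCCN)n2)cc1`: in this assay compound 2 gives 43%

Compound 2 stands highest of the two numbers, but its nearest neighbour is compound 1 and the step of a number 5 percentage points higher from compound 1 to compound 2 (within the scatter) is within the scatter, so the two cannot be ordered. That step, 1,5-diaminopentyl in place of 3-aminocyclopentyl on an aromatic carbon, is the only one measured.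

Compound 3 `CCCCCCCCCCc1ccc(-c2noc([C@H](N)CCCCN)n2)cc1` follows from compound 2 by the two compounds have the same atoms and bonds and differ only in configuration as drawn: 1 of 1 stereo elements differ; a stereocentre at a saturated chain carbon is drawn S in compound 2 and R in compound 3. Among the compounds with values here, no measured step bears on a change of configuration alone, and the single step in hand concerns a different change, so nothing in the numbers sets the size or direction of this change. The step is therefore expected to be a number 8 percentage points lower from compound 2 to compound 3 (within the scatter), small and with wide uncertainty. In this assay compound 3 is estimated at 35%, expected to fall between 10% and 60%.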

Compound 3, a percentage reported as inhibition, at one concentration (the size of the read-out at that concentration, not a potency): 50%
Compound 3: middle estimate off by 15 percentage points, on the low side; low and high end bracket the measured number.
By their numbers in this assay, from the lowest: compounds 1, 2 and 3 (each within the scatter of the next, the first and the last beyond it).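

Changing only the drawn configuration at the saturated chain carbon gives a number 7 percentage points higher from compound 2 to compound 3 (within the scatter) in this assay, so this position shows no configuration preference that can be told apart from the scatter. The pair reads on configuration alone: the fact that compounds 2 and 3 differ only in the configuration as drawn. Within the data shown here, the 1,5-diaminopentyl group in place of 3-aminocyclopentyl gives a number 12 percentage points higher from compound 1 to compound 3 (beyond the scatter) when drawn R, the only step beyond the scatter, whereas the same exchange drawn S stayed within it.

Going by these compounds, whether a carboxylic acid or a hydroxyl group in place of one amine of the 1,5-diaminopentyl group, or a longer chain at this position, would keep or change the inhibition remains open. With readings at a single concentration, the compounds shown also leave the potency of all three open.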